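A Smaller Side Chain at the Clearance Limit

The compounds below may be only part of what the source reports. "The series", "measured", "known", "first", "only" and "open" are said of these compounds alone.

In an ADME assay on liver (Rattus norvegicus) for metabolic stability, read by LC-MS, using S9 fraction and NADPH, with a stated time of 30 min, tested at 5 uM, in the presence of a further agent that is not named here (a lower number here means slower removal, a higher number faster removal of the compound), compound 2 (`O/N=C(\Nc1ccc(F)c(Br)c1)c1nonc1NCc1ccccc1`) reads > 36.6 mL/min/kg as a limit of the assay and not as a number. Compound 1 (`CN(C)c1nonc1/C(=N/O)Nc1ccc(F)c(Br)c1`) also reads > 36.6 mL/min/kg as a limit. Among the measured compounds shown here, the only measured step is thus a step that the two limits leave unreadable from compound 1 to compound 2 and offers no size to carry over. Compound 3 (`COCCNc1nonc1/C(=N/O)Nc1ccc(F)c(Br)c1`) differs from compound 2 by methoxymethyl in place of phenyl on a saturated chain carbon bound to a nitrogen on an aromatic ring so that benzyl becomes 2-methoxyethyl. No step beyond the scatter is expected in this assay and the estimated size is a step that the limit leaves unreadable from compound 2 to compound 3 in this comparison. Compound 3 is estimated at 40 mL/min/kg with a range from 22 mL/min/kg to 70 mL/min/kg. A limit rather than a number is expected to remain possible for compound 3.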

Compound 3, clearance: > 36.6 mL/min/kg
Compound 3: only a limit was reported (the forecaster's own chance of this, stated with the estimate: 70%); the middle value does not contradict the limit.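

No step can be read among compound 1, compound 2 and compound 3, because each result is a limit and not a number: the limit of > 36.6 mL/min/kg in this assay, at which 3 of the 3 values shown sit.

On these data alone, how fast each compound is actually removed, and whether their side chains change that, stays open.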